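Sulfonyl aryl groups swapped for oxan-4-yl in a ghrelin receptor agonist

This account rests on a few compounds, and the source may have more. Where it says the series, first, only, none or still open, it means among the compounds named here.

Measured compounds:
compound 1 `Cc1ccc2[nH]c(C(=O)N[C@H]3CN(S(=O)(=O)c4ccccc4)C[C@@H]3C(=O)NCCN(C)C)cc2c1` gives 93%
compound 2 `Cc1ccc2[nH]c(C(=O)N[C@H]3CN(S(=O)(=O)c4cccnc4)C[C@@H]3C(=O)NCCN(C)C)cc2c1` gives 90%
compound 3 `Cc1ccc2[nH]c(C(=O)N[C@H]3CN(S(=O)(=O)c4ccnc(C)c4)C[C@@H]3C(=O)NCCN(C)C)cc2c1` gives 91%

The three compounds were tested in a functional assay on HEK293 cells for agonist activity at growth hormone secretagogue receptor type 1 (Homo sapiens), read by HTRF and inositol phosphate accumulation, with a stated time of 90 min, in the presence of a further agent that is not named here; on this read-out higher numbers stand for larger maximal responses and lower numbers for smaller maximal responses. Compound 3 stands second highest of the three numbers, its nearest neighbour being compound 2 a number 1 percentage points higher from compound 2 to compound 3 (within the scatter), while the furthest is compound 1 a number 2 percentage points lower from compound 1 to compound 3 (within the scatter). The remaining pair, compound 1 and compound 2, differs likewise a number 3 percentage points lower from compound 1 to compound 2 (within the scatter). All three steps lie within the usual scatter, so the numbers shown do not separate the compounds from one another.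

Compound 4 `Cc1ccc2[nH]c(C(=O)N[C@H]3CN(S(=O)(=O)C4CCOCC4)C[C@@H]3C(=O)NCCN(C)C)cc2c1` is not yet measured. It differs from compound 3 as follows: oxan-4-yl in place of 2-methylpyridin-4-yl on a sulfonyl sulfur. The measured steps all concern the same place, the group on the sulfonyl sulfur, and each of them was within the scatter, so a fourth variation at this place is expected to behave in the same way in this assay, with no step beyond the scatter in either direction. On that basis compound 4 is estimated to give 89% in this assay, with a range from 76% to 99%. This estimate means a step of a number 2 percentage points lower from compound 3 to compound 4 (within the scatter) that is expected to stay within the scatter.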

Compound 4, largest response reached (Emax), in percent of the reference or control that the assay uses: 90%
Compound 4: the middle estimate sits 1 percentage points below what was measured; the range from low to high includes it.
By their numbers in this assay, from the lowest: compounds 2, 4, 3 and 1 (each within the scatter of the next).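

Among these compounds, compound 4 is the first compound here with a non-aromatic ring on the sulfonyl sulfur, and in this assay the oxan-4-yl group stays within the scatter of all three aromatic groups, whichever one it replaces: the comparisons give a number 1 percentage points lower from compound 3 to compound 4 (within the scatter), then no change at the digits printed from compound 2 to compound 4 (within the scatter), and finally a number 3 percentage points lower from compound 1 to compound 4 (within the scatter). The earlier compounds varied this place only among phenyl, pyridin-3-yl and 2-methylpyridin-4-yl, whereas compound 4 shows that, among the four compounds shown, an aromatic ring at this place is not required for a maximal response at the level of the other three. No measurement shown here bears on why the four compounds cannot be separated at this place.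

Since this read-out gives only the largest response reached, the compounds leave open whether the groups differ in the concentration needed to reach that response. They also leave open whether the same holds for a group without a ring, such as a short alkyl chain, or for a ring carrying a basic amine or a carboxylic acid.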